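Removing the terminal phosphate from a phenethylthio uridine nucleotide

A few compounds are considered here, and "the series" means these few. Any claim that something is new, unique, unknown or untested is made for them only; others in the source may bear on it.

In an in vitro functional assay on 1321-N1 cells for agonist activity at P2Y purinoceptor 4 (Homo sapiens), read by scintillation proximity assay and inositol phosphate accumulation (on this read-out higher numbers stand for an effect only at larger amounts of compound and lower numbers for an effect already at smaller amounts), compound 1 `O=c1ccn([C@@H]2O[C@H](COP(=O)(O)OP(=O)(O)O)[C@@H](O)[C@H]2O)c(SCCc2ccccc2)n1` gives >= 100000 nM, which is a limit of the assay rather than a number. Among the measured compounds shown here, compound 2 `CCCSc1nc(=O)ccn1[C@@H]1O[C@H](COP(=O)(O)OP(=O)(O)O)[C@@H](O)[C@H]1O` gives 4900 nM in this assay, so the step of an at least 20-fold lower number from compound 1 to compound 2 (1.30 log units; beyond the scatter) is the only change measured in a single place. Compound 3 `O=c1ccn([C@@H]2O[C@H](COP(=O)(O)O)[C@@H](O)[C@H]2O)c(SCc2ccccc2)n1` gives > 100000 nM in this assay, again a limit. Compound 4 `O=c1ccn([C@@H]2O[C@H](COP(=O)(O)O)[C@@H](O)[C@H]2O)c(SCCc2ccccc2)n1` differs from compound 1 by a hydrogen atom in place of a group of 4 heavy atoms (3 oxygen, 1 phosphorus; no ring), on an oxygen. For the measured compounds named here, no measured step covers that change; the closest comparison is compound 3, which also lacks that group and sits at a limit (the limit of > 100000 nM in this assay, at which 1 of the 3 values shown sits). Compound 1 itself sits at a limit (the limit of >= 100000 nM in this assay, at which 1 of the 3 values shown sits). Compound 4 is therefore expected to remain at a limit, and the expected step that the limit leaves unreadable from compound 1 to compound 4 carries little weight. The estimate for compound 4 is 300000 nM, between 100000 nM and 3000000 nM.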

Compound 4, half-maximal effective concentration: > 100000 nM
Compound 4: a limit, no number; the forecaster's own chance of this, stated with the estimate: 90%; the middle value does not contradict the limit.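

Compound 4 ends at a limit, as do compound 1 and compound 3, so its steps from both cannot be read. The compounds shown leave open whether losing the terminal phosphate changes the read-out at all.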